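This account rests on a few compounds, and the source may have more. Where it says the series, first, only, none or still open, it means among the compounds named here.

Measured so far:
Compound 1, `CC1(C)CC(NC(=S)Nc2cccc(Cl)c2)c2cc(Br)ccc2O1`, with 9000 nM in a functional assay on T98G cells (Homo sapiens) for inhibition, read by MTT assay, with a stated time of 72 h; on this read-out higher numbers stand for weaker inhibition and lower numbers for stronger inhibition.
Compound 2, `COc1ccccc1NC(=S)NC1CC(C)(C)Oc2ccc(Br)cc21`, with 42000 nM in this assay.

Compound 2 stands highest of the two numbers in this assay; its nearest neighbour is compound 1, and the pair differ by a 4.7-fold higher number from compound 1 to compound 2 (0.67 log units; beyond the scatter), a step that swaps 2-methoxyphenyl in for 3-chlorophenyl on an amide-type nitrogen. Compound 3, `CC1(C)CC(NC(=S)Nc2ccccc2Cl)c2cc(Br)ccc2O1`, is not yet measured in this assay. It differs from compound 2 as follows: chloro in place of methoxy on an aromatic carbon. Within the data shown here, the only measured step that bears on this change is a 4.7-fold higher number from compound 1 to compound 2 (0.67 log units; beyond the scatter), and it bears only loosely, since it alters both the group and its position at once, whereas compound 3 keeps the position and changes only the group. That step was modest in size. With chloro present in compound 1, which gives 9000 nM, and methoxy present in compound 2, which gives 42000 nM, a move back toward a lower number seems plausible, but the evidence is thin, so the expected step is a 2.1-fold lower number from compound 2 to compound 3 (0.32 log units; beyond the scatter), with the direction uncertain. Compound 3 is therefore estimated at 20000 nM, within a range from 6000 nM to 60000 nM.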

Compound 3, half-maximal inhibitory concentration: 8000 nM
Compound 3: the middle estimate sits 2.5-fold (0.40 log units) above what was measured; the range from low to high includes it.
By their numbers in this assay, from the lowest: compounds 3 and 1 (each within the scatter of the next); then compound 2.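

In this assay, the exchange of methoxy for chloro on the same aromatic carbon, ortho to a large group, now stands on its own as a 5.3-fold lower number from compound 2 to compound 3 (0.72 log units; beyond the scatter) and is thus separated from the change of place that the earlier step carried along with it. The shift from 3-chlorophenyl to 2-chlorophenyl gives a 1.1-fold lower number from compound 1 to compound 3 (0.05 log units; within the scatter) and so leaves the two chloro compounds indistinguishable here; among these three compounds, the clearly higher number goes with the 2-methoxyphenyl group, whichever of these two places the chloro occupies. Nothing available explains why methoxy and chloro part in this way.

The compounds shown leave open how other groups on this aromatic carbon, such as an amine, a hydroxy group or a carboxylic acid, would read beside chloro and methoxy. They also leave open whether methoxy and chloro would keep this gap on a different core, and whether methoxy in the position of the chloro of compound 1 would carry the same penalty.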